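The source may report more compounds than this note shows. Statements on the series, on what has been measured and on what is new or still open speak of the compounds shown alone.

Notes on the series in a functional assay on Bel-7402 cells (Homo sapiens) for antiproliferative activity, read by MTT assay, with a stated time of 48 h; on this read-out lower numbers stand for stronger inhibition of growth and higher numbers for weaker inhibition of growth.

Compound 1 `COc1ccc(/C=C2\Cc3c(cc(OC)c(OC)c3OC)C2=O)cc1O` gives 307 nM in this assay. Compound 2 `COc1ccc(/C=C2\Cc3c(cc(OC)c(OC)c3OC)C2=O)cc1OC` gives 10500 nM. Among the measured compounds shown here, the one change between them is methyl in place of hydrogen on an oxygen on an aromatic ring, and it produced a 34-fold higher number from compound 1 to compound 2 (1.53 log units; beyond the scatter). For the measured compounds named here, with only this pair, it stays a single observation for that change.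

Compound 3 `COc1cc2c(cc1O)C(=O)/C(=C/c1ccc(OC)c(OC)c1OC)C2` is built from the same atoms as compound 1, joined differently; the difference between the two cores is not broken down here. Compound 3 gives 9650 nM, which lies within the scatter of compound 2 and far from compound 1.

Compound 4 `COc1cc2c(cc1OC)C(=O)/C(=C/c1ccc(OC)c(OC)c1OC)C2` is not yet measured. It differs from compound 3 by methyl in place of hydrogen on an oxygen on an aromatic ring, and the place is the same as in the step from compound 1 to compound 2, so it is the same change carried onto the core of compound 3. The earlier step, a 34-fold higher number from compound 1 to compound 2 (1.53 log units; beyond the scatter), was large, but compound 3 already starts where compound 2 ends, and nothing shows that the change weighs as heavily on this second core. Going by the values given here, the expectation for compound 4 is therefore a smaller step in the same direction, a 2.6-fold higher number from compound 3 to compound 4 (0.41 log units; beyond the scatter), resting on compound 3 at 9650 nM and on the single precedent a 34-fold higher number from compound 1 to compound 2 (1.53 log units; beyond the scatter). Compound 4 is estimated to give 25000 nM, expected between 8000 nM and 100000 nM.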

Compound 4, concentration for 50% growth inhibition: > 10000 nM
Compound 4 was reported as a limit; the forecaster's own chance of this, stated with the estimate: 20%; the middle value lies beyond the limit too.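

Compound 4 is reported in this assay only as a limit, > 10000 nM, and not as a number. Read from that limit, the step is an at least 1.0-fold higher number from compound 3 to compound 4 (0.01 log units; that floor lies within the scatter), which is a floor and not a size, so the same change cannot be compared in size on the two cores: the same change on two cores in this assay, a 34-fold higher number (1.53 log units; beyond the scatter) from compound 1 to compound 2 and an at least 1.0-fold higher number (0.01 log units; that floor lies within the scatter) from compound 3 to compound 4; the limit leaves it open whether they differ The change from hydroxy to methoxy therefore has a measured size on the core of compound 1 alone, and on the core of compound 3 it is neither shown to carry over at a like size nor shown to fail to carry over.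

The compounds shown leave open whether a group other than methyl on that oxygen, such as ethyl or an acetyl group, or an amine in place of the hydroxy, would follow the same course on either core. Also open is what separates the two cores: compound 1 and compound 3 differ in more than one place, and no compound shown breaks that gap down.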